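Methyl Replaces Hydrogen on the Benzoyl Ring

The source may hold more compounds than are shown below. What is called first, only, known or untested is meant among the compounds shown, and "the series" means these compounds.

Measured compounds:
Compound 1, `COc1cc(-c2nnc3n2NC(c2ccco2)C(C(=O)c2ccc(F)cc2)S3)cc(OC)c1OC`: in a functional assay on MCF7 cells (Homo sapiens) for cytotoxicity, read by MTT assay, with a stated time of 48 h (on this read-out higher numbers stand for weaker inhibition and lower numbers for stronger inhibition), compound 1 gives > 100000 nM, which is a limit of the assay and not a number.
Compound 2, `COc1cc(-c2nnc3n2NC(c2ccco2)C(C(=O)c2ccccc2)S3)cc(OC)c1OC`: in this assay compound 2 gives 39800 nM.

Compound 2 therefore stands on the only number shown; the other value is a limit. Going by the values given here, the one measured step runs from compound 1 to compound 2 and reads an at least 2.5-fold lower number from compound 1 to compound 2 (0.40 log units; beyond the scatter), a change of hydrogen in place of fluoro on an aromatic carbon. Its size rests on (the limit of > 100000 nM in this assay, at which 1 of the 2 values shown sits), so only its lower bound is known.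

Compound 3, `COc1cc(-c2nnc3n2NC(c2ccco2)C(C(=O)c2ccc(C)cc2)S3)cc(OC)c1OC`, is not yet measured. It differs from compound 2 by methyl in place of hydrogen on an aromatic carbon. Among the compounds with values here, no measured step swaps hydrogen for methyl at this carbon, and the single step recorded touches a different group at the same place. On that footing, compound 3 is expected to sit close to compound 2, with a step of a 1.0-fold higher number from compound 2 to compound 3 (0.00 log units; within the scatter) that is not expected to pass beyond the scatter. Compound 3 is estimated at 40000 nM, within 15000 nM to 100000 nM.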

Compound 3, half-maximal inhibitory concentration: > 100000 nM
Compound 3: no number, only a limit (the forecaster's own chance of this, stated with the estimate: 25%); at least 2.5-fold (0.39 log units) between middle value and limit.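

In this assay, a single methyl on the aromatic carbon para to a large group gives an at least 2.5-fold higher number from compound 2 to compound 3 (0.40 log units; beyond the scatter), so this carbon does not accept every small addition to the benzoyl ring. Fluoro and methyl now both move the read-out the same way from hydrogen at this carbon, and among the three compounds only compound 2, which carries hydrogen there, gives an actual number, 39800 nM. The value of compound 3 is a limit of the assay and not a number, like that of compound 1, so the step between those two compounds cannot be read, and the step from compound 2 gives only a lower bound on the size of the change, because it rests on a limit: the limit of > 100000 nM in this assay, at which 2 of the 3 values shown sit.

The compounds shown leave open how far past the limit compound 1 and compound 3 lie, and so which of fluoro and methyl costs more. They also leave open whether a methoxy group, an amine or a carboxylic acid at this carbon would give a measurable number, and whether methyl on another carbon of the same ring would behave the same way.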